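The source may hold more compounds than are shown below. What is called first, only, known or untested is meant among the compounds shown, and "the series" means these compounds.

Compound 3 `COc1ccc(-c2nc(SC)nc(NCCCCNc3ccnc4cc(Cl)ccc34)c2C#N)cc1` belongs to a set of three compounds built on a shared core, differing only in the group attached to one aromatic carbon. In an ADME assay on CCRF-CEM cells (Homo sapiens) for inhibition, read by cell counting (a lower number here means a stronger inhibitor, a higher number a weaker inhibitor), compound 3 gives 2700 nM, which is the second highest of the three numbers. Compound 1 `CSc1nc(NCCCCNc2ccnc3cc(Cl)ccc23)c(C#N)c(-c2ccccc2)n1` gives 5200 nM in this assay, and compound 2 `CSc1nc(NCCCCNc2ccnc3cc(Cl)ccc23)c(C#N)c(-c2cccc([N+](=O)[O-])c2)n1` gives 2100 nM. The steps among them are a 2.5-fold lower number from compound 1 to compound 2 (0.39 log units; beyond the scatter), a 1.9-fold lower number from compound 1 to compound 3 (0.28 log units; within the scatter) and a 1.3-fold higher number from compound 2 to compound 3 (0.11 log units; within the scatter).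

Compound 4 `COc1ccc(-c2nc(SC)nc(NCCCCNc3ccnc4cc(Cl)ccc34)c2C#N)cc1OC` differs from compound 3 in one place: methoxy in place of hydrogen on an aromatic carbon. The step that speaks most directly to this change is a 1.9-fold lower number from compound 1 to compound 3 (0.28 log units; within the scatter), since it adds the same kind of group to the same ring and stayed within the scatter of repeated measurements. On that basis no movement beyond the scatter is expected, and the expected step is a 1.2-fold lower number from compound 3 to compound 4 (0.07 log units; within the scatter). Compound 4 is therefore estimated at 2300 nM, with a range from 1000 nM to 5500 nM.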

Compound 4, half-maximal inhibitory concentration: 16000 nM
Compound 4: middle estimate off by 7.0-fold (0.84 log units), on the low side, outside the stated range (above it).
By their numbers in this assay, from the lowest: compounds 2, 3 and 1 (each within the scatter of the next, the first and the last beyond it); then compound 4.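

In this assay the second methoxy behaves unlike the first: the step is a 5.9-fold higher number from compound 3 to compound 4 (0.77 log units; beyond the scatter) and points to a weaker inhibitor, whereas the first methoxy, added to compound 1, moved the number only within the scatter. The 3,4-dimethoxyphenyl group also falls behind both other groups, with a 3.1-fold higher number from compound 1 to compound 4 (0.49 log units; beyond the scatter) and a 7.6-fold higher number from compound 2 to compound 4 (0.88 log units; beyond the scatter) in the same direction, so the effects of methoxy groups on this ring do not simply add up. Nothing measured here accounts for this jump.

Still open, on these data alone, is whether the loss belongs to a methoxy at this carbon alone or only to the two methoxy groups together. Also open, as far as these compounds go, is whether a hydroxyl, a fluorine or an amine at this carbon would give the same loss.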